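A few compounds are considered here, and "the series" means these few. Any claim that something is new, unique, unknown or untested is made for them only; others in the source may bear on it.

Compound 1 `Cc1c(OCCCCOCOc2ccc(C(=O)O)cc2)ccc(C(=O)CC2CCCC2)c1O` gives 228 nM in an assay on HEK293 cells for positive allosteric modulation of metabotropic glutamate receptor 2 (Rattus norvegicus), read by thallium flux, with a stated time of 2.5 min; a higher number here means that more compound is needed for the effect, a lower number that less compound is needed. Compound 2 `Cc1c(OCCCCOc2ccccc2C(=O)O)ccc(C(=O)CC2CCCC2)c1O` gives 335 nM, and compound 3 `Cc1c(OCCCCOc2ccc(C(=O)O)c(Cl)c2)ccc(C(=O)CC2CCCC2)c1O` gives 510 nM. Compound 3 thus has the highest number of the three: the step of a 1.5-fold higher number from compound 2 to compound 3 (0.18 log units; within the scatter) stays within the scatter, while the step of a 2.2-fold higher number from compound 1 to compound 3 (0.35 log units; beyond the scatter) lies beyond it, though only modestly. The step of a 1.5-fold higher number from compound 1 to compound 2 (0.17 log units; within the scatter) is likewise within the scatter.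

Compound 4 `Cc1cc(OCCCCOc2ccc(C(=O)CC3CCCC3)c(O)c2C)ccc1C(=O)O` has not yet been measured. Against compound 3 its change is methyl in place of chloro on an aromatic carbon, on a six-membered aromatic ring of carbon only, ortho to the carboxy group and meta to a large group. Within the data shown here, none of the three measured steps touches this position: they exchange the whole aryl group rather than a single substituent on it, so no measured step bears directly on the swap of chloro for methyl. The three measured values span only a narrow range, and a one-atom exchange of this kind gives no reason to expect a departure from it. Compound 4 is therefore expected to show no step beyond the scatter, with the estimated step of a 1.1-fold lower number from compound 3 to compound 4 (0.05 log units; within the scatter). For compound 4 the estimate in this assay is 450 nM, with a range from 200 nM to 1000 nM.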

Compound 4, half-maximal effective concentration: 564 nM
Compound 4: the middle estimate sits 1.3-fold (0.10 log units) below what was measured; low and high end bracket the measured number.
By their numbers in this assay, from the lowest: compounds 1, 2, 3 and 4 (each within the scatter of the next, the first and the last beyond it).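

In this assay, among these compounds, the exchange of chloro for methyl on the aromatic carbon ortho to the carboxy group gives a 1.1-fold higher number from compound 3 to compound 4 (0.04 log units; within the scatter) and is the first step here that changes a single substituent on the aryl group rather than the whole group, showing that these two groups cannot be told apart at this place. Compound 4 also relates to the other two compounds much as compound 3 does: a 1.7-fold higher number from compound 2 to compound 4 (0.23 log units; within the scatter) remains within the scatter, while a 2.5-fold higher number from compound 1 to compound 4 (0.39 log units; beyond the scatter) lies modestly beyond it. Nothing measured here accounts for the close agreement between chloro and methyl.

The compounds shown leave open what a hydrogen, a methoxy group or an amine on this aromatic carbon would do to the number, as only chloro and methyl can be compared there. They also leave open whether a chloro or methyl group would read the same on the 2-carboxyphenyl group of compound 2, and whether the result would hold with a longer chain between the aryl group and the shared core.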